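Amine replacements in a cytotoxicity series

The source may hold more compounds than are shown below. What is called first, only, known or untested is meant among the compounds shown, and "the series" means these compounds.

Measured so far:
compound 1, `COc1ncc(-c2ccc3nccc(C#CCN(C)C)c3c2)cc1NS(=O)(=O)c1ccc(F)cc1F`, 1670 nM
compound 2, `CCN(CC)CC#Cc1ccnc2ccc(-c3cnc(OC)c(NS(=O)(=O)c4ccc(F)cc4F)c3)cc12`, 2680 nM
compound 3, `COc1ncc(-c2ccc3nccc(C#CCN(C4CCCCC4)C4CCCCC4)c3c2)cc1NS(=O)(=O)c1ccc(F)cc1F`, 27700 nM

All three were tested in a functional assay on MDA-MB-231 cells (Homo sapiens) for cytotoxicity, read by MTT assay, with a stated time of 72 h; a lower number here means a stronger inhibitor, a higher number a weaker inhibitor. Compound 1 gives the lowest number of the three in this assay; compound 2 lies within the scatter of it, while compound 3 lies well above it. For the measured compounds named here, the only single-point step known, a 1.6-fold higher number from compound 1 to compound 2 (0.21 log units; within the scatter), is within the scatter. Compound 4, `COc1ncc(-c2ccc3nccc(C#CCN4CCC(C)CC4)c3c2)cc1NS(=O)(=O)c1ccc(F)cc1F`, differs from compound 1 by 4-methylpiperidin-1-yl in place of dimethylamino on a saturated chain carbon bound to a triple-bonded carbon. This change touches the same amine as the step to compound 2, and compound 3 shows what a far larger amine gave at that place. A modest rise in the number is therefore expected, a 2.1-fold higher number from compound 1 to compound 4 (0.32 log units; beyond the scatter). The estimate for compound 4 in this assay is 3500 nM, with a range from 1500 nM to 8500 nM.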

Compound 4, half-maximal inhibitory concentration: 7990 nM
Compound 4: middle estimate off by 2.3-fold (0.36 log units), on the low side, within the range that was stated.
By their numbers in this assay, from the lowest: compounds 1 and 2 (each within the scatter of the next); then compound 4; then compound 3.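

In this assay the 4-methylpiperidin-1-yl group gives a rise beyond the scatter from both open-chain amines (a 4.8-fold higher number from compound 1 to compound 4 (0.68 log units; beyond the scatter)) and (a 3.0-fold higher number from compound 2 to compound 4 (0.47 log units; beyond the scatter)). This position therefore separates these amines, although dimethylamino and diethylamino stayed within the scatter of each other. The ring amine of compound 4 still gives a lower number than the larger amine of compound 3 (27700 nM). No measured evidence explains the rise.

Open, from the compounds shown here alone, is whether the rise follows the ring or its methyl. Piperidin-1-yl without the methyl, or morpholin-4-yl, on the same saturated chain carbon would bear on that.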